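Swapping the pyridine ring for an oxane at the amine

The source may hold more compounds than are shown below. What is called first, only, known or untested is meant among the compounds shown, and "the series" means these compounds.

Measured compounds:
Compound 1 `COc1ccc(-c2c(C)nc3c(NCc4ccc(C(N)=O)cc4)nc(C)cn23)cc1OC`: 9 ug/mL
Compound 2 `COc1ccc(-c2c(C)nc3c(NCc4cccnc4)nc(C)cn23)cc1OC`: 58 ug/mL

In a physicochemical assay for solubility, measured as thermodynamic solubility, at pH 6.9 (on this read-out lower numbers stand for lower solubility and higher numbers for higher solubility), compound 2 gives the higher of the two numbers; the nearest is compound 1 with 9 ug/mL. Within the data shown here, the one step known here, a 6.4-fold higher number from compound 1 to compound 2 (0.81 log units; beyond the scatter), alters the same position that is now changed again. Compound 3 `COc1ccc(-c2c(C)nc3c(NCC4CCOCC4)nc(C)cn23)cc1OC` differs from compound 2 by oxan-4-yl in place of pyridin-3-yl on a saturated chain carbon bound to a nitrogen on an aromatic ring. Among the measured compounds shown here, no step with an oxan-4-yl group at this position has been measured, so the step from compound 1 to compound 2 only shows that the group at this place can move this read-out by a modest amount, without telling the direction for an oxane ring. With that, the expected step of a 1.2-fold lower number from compound 2 to compound 3 (0.06 log units; within the scatter) is small and not beyond the scatter. Compound 3 is therefore estimated at 50 ug/mL in this assay, with a range from 15 ug/mL to 160 ug/mL.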

Compound 3, solubility: 10 ug/mL
Compound 3: middle estimate off by 5.0-fold (0.70 log units), on the high side; measured number outside the range, below it.
By their numbers in this assay, from the lowest: compounds 1 and 3 (each within the scatter of the next); then compound 2.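

In this assay, the oxan-4-yl group does not keep the number reached with pyridin-3-yl, and the change gives a 5.8-fold lower number from compound 2 to compound 3 (0.76 log units; beyond the scatter). Two six-membered rings with 6 heavy atoms and 1 hydrogen-bond acceptor each are therefore not interchangeable on this saturated chain carbon. The change from the 4-carbamoylphenyl group gives a 1.1-fold higher number from compound 1 to compound 3 (0.05 log units; within the scatter), which leaves compound 2 as the only one of the three set apart by steps beyond the scatter, and nothing measured here accounts for the gap between the rings.

The compounds shown leave open whether the number for compound 2 belongs to pyridine rings in general or to pyridin-3-yl alone, which a pyridin-4-yl group would test. They also do not say how a piperidin-4-yl ring, an amine, would compare with the oxan-4-yl group at this place.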